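Squaramide series: shortening the nitrogen substituent of compound 1

The source may report more compounds than this note shows. Statements on the series, on what has been measured and on what is new or still open speak of the compounds shown alone.

Measured compounds in a functional assay for inhibition, with Rattus norvegicus as the target; on this read-out higher numbers stand for weaker inhibition and lower numbers for stronger inhibition:
- compound 1 `CC[C@H](C)/N=c1\c(O)c(O)\c1=N/Cc1ccc(C#N)cc1`: 2200 nM
- compound 2 `CCc1cc(C/N=c2\c(O)c(O)\c2=N/C(C)(C)C)ccc1C#N`: 6100 nM
- compound 3 `CC(/N=c1\c(O)c(O)\c1=N/Cc1ccc(Cl)cc1Cl)C(C)(C)C`: 340 nM

Compound 1 stands second highest of the three numbers. Its nearest neighbour is compound 2, whose value is higher by a gap beyond the usual scatter; furthest away is compound 3, whose lower value marks it as the strongest inhibitor of the three. No single-change pairs exist among these three, so no measured step can be quoted for any one structural alteration.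

Compound 4 `C/N=c1\c(O)c(O)\c1=N/Cc1ccc(C#N)cc1` differs from compound 1 in one place: methyl in place of sec-butyl on a double-bonded nitrogen. The branched, four-carbon group on the double-bonded nitrogen gives way to a single carbon. Among the measured compounds, the branched groups at this nitrogen in compound 2 and compound 3 accompany both weaker and stronger inhibition, so the direction of this change is not pinned down by the data. A modest weakening seems the more likely outcome, and the expected step from compound 1 to compound 4 in this assay is a 2.7-fold higher number from compound 1 to compound 4 (0.44 log units; beyond the scatter). Compound 4 is expected to give 6000 nM, estimated within 2000 nM to 20000 nM.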

Compound 4, half-maximal inhibitory concentration: > 30000 nM
Compound 4 gave a limit, no number; the forecaster's own chance of this, stated with the estimate: 10%; middle value at least 5.0-fold (0.69 log units) away from the limit.
By their numbers in this assay, from the lowest: compound 3; then compound 1; then compound 2. At a limit, above all of these: compound 4.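

In this assay, compound 4 reads > 30000 nM, which is a limit of the assay and not a number. Methyl in place of sec-butyl on a double-bonded nitrogen gives an at least 13-fold higher number from compound 1 to compound 4 (1.13 log units; beyond the scatter), the only single-change step shown in this series and a large one. Going by these compounds alone, with the rest of compound 1 held constant, inhibition therefore depends strongly on the group at this nitrogen, something the earlier compounds, which differ in more than one place, could not show.

The compounds shown leave open how inhibition changes between methyl and sec-butyl, for instance with ethyl or a propyl chain on this nitrogen, and whether the defined stereocentre that leaves with sec-butyl plays any part. As far as these compounds go, whether a cyclobutyl ring or a chain bearing an amine would be accepted here also remains open.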